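The source may report more compounds than this note shows. Statements on the series, on what has been measured and on what is new or still open speak of the compounds shown alone.

For the measured compounds named here, compound 3 `Cn1c(=O)c(C(=O)Nc2ccc(F)cc2F)cc2cnc(Nc3ccc4[nH]ccc4c3)nc21` carries a (2,4-difluorophenyl)carbamoyl group on the shared core and, in a functional assay on K562 cells (Homo sapiens) for inhibition, read by trypan blue exclusion, with a stated time of 72 h (a higher number here means a weaker inhibitor, a lower number a stronger inhibitor), compound 3 gives 5000 nM, the highest of the three numbers measured so far. Its nearest neighbour is compound 2 `Cn1c(=O)c(S(=O)(=O)Cc2ccc(F)cc2F)cc2cnc(Nc3ccc4[nH]ccc4c3)nc21`, which in this assay gives 1000 nM; compound 1 `Cn1c(=O)c(S(=O)(=O)c2ccc(F)cc2[N+](=O)[O-])cc2cnc(Nc3ccc4[nH]ccc4c3)nc21` gives 900 nM. Compounds 1 and 2 differ only in the group on the sulfonyl sulfur, and that step, a 1.1-fold higher number from compound 1 to compound 2 (0.05 log units; within the scatter), lies within the scatter. Compound 4 `Cn1c(=O)c(S(=O)(=O)Nc2ccc(F)cc2)cc2cnc(Nc3ccc4[nH]ccc4c3)nc21` is reached from compound 3 by (4-fluorophenyl)sulfamoyl in place of (2,4-difluorophenyl)carbamoyl on an aromatic carbon. Going by the values given here, no measured step changes exactly this part of the molecule, so the only guide is the gap between compound 3 and the two sulfonyl compounds, which is beyond the scatter and places the (4-fluorophenyl)sulfamoyl group of compound 4 between the two kinds of measured substituent. Compound 4 is therefore expected to give a lower number than compound 3, a step of about a 2.5-fold lower number from compound 3 to compound 4 (0.40 log units; beyond the scatter) in this assay. The estimate for compound 4 in this assay is 2000 nM, with a range from 600 nM to 6000 nM.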

Compound 4, half-maximal inhibitory concentration: 5000 nM
The estimate for compound 4 lay 2.5-fold (0.40 log units) below the measured number; the range from low to high includes it.
By their numbers in this assay, from the lowest: compounds 1 and 2 (each within the scatter of the next); then compounds 3 and 4 (each within the scatter of the next).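

Putting (4-fluorophenyl)sulfamoyl in place of (2,4-difluorophenyl)carbamoyl on this aromatic carbon gives no change at the digits printed from compound 3 to compound 4 (within the scatter) in this assay, so among these compounds a sulfonyl sulfur at this position does not by itself go with the lower numbers. On that sulfur, (4-fluorophenyl)amino in place of 2,4-difluorobenzyl gives a 5.0-fold higher number from compound 2 to compound 4 (0.70 log units; beyond the scatter), and in place of 4-fluoro-2-nitrophenyl it gives a 5.6-fold higher number from compound 1 to compound 4 (0.74 log units; beyond the scatter), showing that the attached group can shift the number, which the step between the two earlier sulfonyl compounds did not show. Nothing available here explains these steps.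

The step from compound 3 to compound 4 alters the carbonyl and the ring fluorine together, and a (2,4-difluorophenyl)sulfamoyl group would separate the two. A 4-fluorobenzyl group on the sulfonyl sulfur would test the nitrogen of compound 4 on its own.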